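Ester and Ether Side Chains on a Shared Core

The source may hold more compounds than are shown below. What is called first, only, known or untested is meant among the compounds shown, and "the series" means these compounds.

Compound 1 `CC(=O)OCCC(=O)O[C@H](CC=C(C)C)C1=CC(=O)c2c(O)ccc(O)c2C1=O` gives 17300 nM in a functional assay on HeLa cells (Homo sapiens) for cytotoxicity, read by MTT assay; a higher number here means a weaker inhibitor, a lower number a stronger inhibitor.
Compound 2 `CC(C)=CC[C@@H](OC(=O)C1CCCCO1)C1=CC(=O)c2c(O)ccc(O)c2C1=O` reaches only the limit > 100000 nM in this assay.
Compound 3 `COCCO[C@H](CC=C(C)C)C1=CC(=O)c2c(O)ccc(O)c2C1=O` gives 62400 nM in this assay.

Among the two numbers, compound 3 stands highest; its nearest neighbour is compound 1, and the step of a 3.6-fold higher number from compound 1 to compound 3 (0.56 log units; beyond the scatter) marks the swap of the ester for the ether. Compound 4 `CCCCC(C)(O)CC(=O)O[C@H](CC=C(C)C)C1=CC(=O)c2c(O)ccc(O)c2C1=O` returns to an ester: (2-hydroxy-2-methylhexyl)carbonyl in place of 2-methoxyethyl on an oxygen on a saturated carbon.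

Among the compounds with values here, two measured steps bear on this change. The step of a 3.6-fold higher number from compound 1 to compound 3 (0.56 log units; beyond the scatter) shows that removing an ester in favour of the ether raised the number. The step of an at least 1.6-fold lower number from compound 2 to compound 3 (0.20 log units; that floor lies within the scatter) runs the other way, though its floor lies within the scatter. The value of compound 2 is a limit (the limit of > 100000 nM in this assay, at which 1 of the 3 values shown sits). So esters can sit on either side of compound 3, and the expected step for compound 4 in this assay is small, leaning toward a lower number.

Compound 4 is estimated at 40000 nM, with a range from 12000 nM to 130000 nM. That estimate corresponds to an expected 1.6-fold lower number from compound 3 to compound 4 (0.19 log units; within the scatter).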

Compound 4, half-maximal inhibitory concentration: 60600 nM
Compound 4: middle estimate off by 1.5-fold (0.18 log units), on the low side; low and high end bracket the measured number.
By their numbers in this assay, from the lowest: compound 1; then compounds 4 and 3 (each within the scatter of the next). At a limit, above all of these: compound 2.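

The step of a 1.0-fold lower number from compound 3 to compound 4 (0.01 log units; within the scatter) shows that the much larger (2-hydroxy-2-methylhexyl)carbonyl, on this oxygen on a saturated carbon, gives a number that cannot be told apart from that of the 2-methoxyethyl ether, so an ester here does not by itself bring the lower number. Among the esters, the step of a 3.5-fold higher number from compound 1 to compound 4 (0.54 log units; beyond the scatter) shows that 1-hydroxy-1-methylpentyl does not match the acetoxymethyl of compound 1. Compound 2 stands at a limit, so the step of an at least 1.6-fold lower number from compound 2 to compound 4 (0.21 log units; that floor lies within the scatter) gives no size for that change: the limit of > 100000 nM in this assay, at which 1 of the 4 values shown sits.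

The compounds shown leave open whether the lower number of compound 1 depends on its acetoxy group or on the length of its chain. They also leave open how an amine or a carboxylic acid at the end of this chain would read.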